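A few compounds are considered here, and "the series" means these few. Any claim that something is new, unique, unknown or untested is made for them only; others in the source may bear on it.

Compound 1, `Cc1nc(SCC(=O)Nc2nc(-c3ccc(Cl)cc3)cs2)n(Nc2ccccc2)c1C`: 3590 nM
Compound 2, `Cc1ccc(Nn2c(SCC(=O)Nc3nc(-c4ccccc4)cs3)nc(C)c2C)cc1`: 2890 nM

Both compounds were tested in a functional assay on UO-31 cells (Homo sapiens) for antiproliferative activity, read by sulforhodamine B assay, with a stated time of 48 h; on this read-out higher numbers stand for weaker inhibition of growth and lower numbers for stronger inhibition of growth. Compound 1 holds the higher of the two numbers, but its gap to compound 2 is within the usual scatter of repeated measurements, so the two results cannot be told apart. Among the measured compounds shown here, compound 2 also differs from compound 1 in more than one place, so the pair shows no single structural step.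

Compound 3, `COc1ccc(Nn2c(SCC(=O)Nc3nc(-c4ccc(Cl)cc4)cs3)nc(C)c2C)cc1`, has not yet been tested. It is made from compound 1 by one change: methoxy in place of hydrogen on an aromatic carbon. For the measured compounds named here, no measured pair of compounds shows the effect of this change, so there is nothing to say whether it helps or hurts; the expectation is a step no larger than the scatter, in either direction. Compound 3 is therefore expected to give 3200 nM, in the range 1200 nM to 8500 nM. That amounts to an expected 1.1-fold lower number from compound 1 to compound 3 (0.05 log units; within the scatter), no change beyond the scatter.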

Compound 3, concentration for 50% growth inhibition: 2620 nM
Compound 3: the middle estimate sits 1.2-fold (0.09 log units) above what was measured; the range from low to high includes it.
By their numbers in this assay, from the lowest: compounds 3, 2 and 1 (each within the scatter of the next).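

Methoxy in place of hydrogen on this aromatic carbon, para to a large group, now has a measured step: in this assay it gives a 1.4-fold lower number from compound 1 to compound 3 (0.14 log units; within the scatter). This position therefore carries methoxy, with its 2 heavy atoms, without any shift in growth inhibition that can be told apart from the usual scatter of repeated measurements. No measurement on hand offers an explanation for this result.

On these data alone, a single small group at a single position says little about the position as a whole, so it stays open whether an amine, a carboxylic acid or a longer chain in the same place would also stay within the scatter. As far as these compounds go, it is also open whether methoxy would give a similar step on a version of the core without the chloro group of compound 1.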